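The compounds below may be only part of what the source reports. "The series", "measured", "known", "first", "only" and "open" are said of these compounds alone.

Working notes on the series in a functional assay on CHO cells for agonist activity at Alpha-1A adrenergic receptor (Homo sapiens), read by FLIPR and calcium flux; a lower number here means a smaller maximal response, a higher number a larger maximal response.

Of the compounds shown here, three have been measured so far. Compound 1 `c1cc(-c2cn[nH]c2)c2c(c1)C(c1ncc[nH]1)CC2` gives 84% in this assay. Compound 3 `Cc1ccc2c(c1NS(C)(=O)=O)CCC2c1ncc[nH]1` gives 83%, a number within the scatter of compound 1, so no order between the two can be read. Compound 2 `Cc1c(OCC2=NCCN2)ccc(Cl)c1NS(C)(=O)=O` gives 60%, a number beyond the scatter and lower than that of compound 1. Compound 1 therefore stands with compound 3 at the upper end of the three numbers, with compound 2 separated from both.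

For the measured compounds named here, no pair of measured compounds differs in one place only, so no counted step within the set is available. The next compound, compound 4 `c1ccc(-c2cccc3c2CCC3c2ncc[nH]2)nc1`, differs from compound 1 by pyridin-2-yl in place of 1H-pyrazol-4-yl on an aromatic carbon.

Without a measured step of this kind in the set, only a loose expectation is possible. A change in the same direction as from compound 1 to compound 2, where compound 2 gives 60%, cannot be ruled out, but the two differ in more than one place. The step from compound 1 to compound 4 is expected to be small, estimated at a number 8 percentage points lower from compound 1 to compound 4 (within the scatter), and may fall within the scatter. Compound 4 is estimated at 76%, with a range from 52% to 96%.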

Compound 4, largest response reached (Emax), in percent of the reference or control that the assay uses: 53%
Compound 4: the middle estimate sits 23 percentage points above what was measured, within the range that was stated.
By their numbers in this assay, from the lowest: compounds 4 and 2 (each within the scatter of the next); then compounds 3 and 1 (each within the scatter of the next).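

In this assay, for the compounds shown here, pyridin-2-yl in place of 1H-pyrazol-4-yl on an aromatic carbon of the shared core gives the first counted step (a number 31 percentage points lower from compound 1 to compound 4 (beyond the scatter)), which shows that the maximal response depends on the aromatic ring carried at this position. The change replaces a five-membered aromatic ring with 2 hetero atoms and 1 hydrogen-bond donor by a six-membered aromatic ring with 1 hetero atom and 0 hydrogen-bond donors, and this single step cannot separate these differences. Nothing at hand accounts for the lower response.

The compounds shown leave open whether the response at this position follows the ring size, the ring nitrogens or the donor. A 1-methyl-1H-pyrazol-4-yl group or a pyridin-4-yl group on the same carbon would bear on that question.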